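A few compounds are considered here, and "the series" means these few. Any claim that something is new, unique, unknown or untested is made for them only; others in the source may bear on it.

Compound 1, `CCCCc1cnc(C(Cc2ccc(-c3ccccc3C(=O)O)cc2)C(C)C)[nH]1`, and compound 2, `O=C(O)c1ccccc1-c1ccc(CCc2ncc(Cc3ccccc3Cl)[nH]2)cc1`, share a core that carries a carboxylic acid on one side and an imidazole on the other, and both have been tested in an in vitro functional assay on cells for agonist activity at Bombesin receptor subtype-3 (Homo sapiens), read by luminescence and calcium flux; a lower number here means that less compound is needed, a higher number that more compound is needed for the effect. In this assay compound 1 gives 4620 nM, while compound 2 gives 292 nM. Of the two numbers, that of compound 2 is the lower one; the gap to compound 1 lies beyond the usual scatter, so compound 2 stands as the more potent of the two measured compounds.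

Compound 3, `O=C(O)c1ccccc1-c1ccc(CCc2ncc(CC3CC3)[nH]2)cc1`, has not yet been measured. It differs from compound 2 in one place: cyclopropyl in place of 2-chlorophenyl on a saturated chain carbon bound to an aromatic carbon. Among the measured compounds shown here, no measured pair in this set shows the effect of such a change, so any expectation rests on the change itself. Removing the 2-chlorophenyl in favour of cyclopropyl is expected to cost potency, and the step of a 5.1-fold higher number from compound 2 to compound 3 (0.71 log units; beyond the scatter) is estimated to lie beyond the scatter, in the direction of a higher number. Compound 3 is therefore expected to give about 1500 nM, within a range from 400 nM to 6000 nM.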

Compound 3, half-maximal effective concentration: 1000 nM
Compound 3: the middle estimate sits 1.5-fold (0.18 log units) above what was measured; the range from low to high includes it.
By their numbers in this assay, from the lowest: compound 2; then compound 3; then compound 1.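

Read in this assay, the exchange of 2-chlorobenzyl for cyclopropylmethyl gives the first measured step at this position, a 3.4-fold higher number from compound 2 to compound 3 (0.53 log units; beyond the scatter), and that step is modest. With the 2-chlorophenyl gone and only a cyclopropyl in its place, on a saturated chain carbon bound to an aromatic carbon, compound 3 still gives a measurable 1000 nM, so an aromatic ring and a chlorine at this position are not needed for a reading in this assay, although compound 2, which carries them, has the lower number. Neither group has hydrogen-bond donors, hydrogen-bond acceptors or a net charge, and nothing measured here explains the size of the step.

From the compounds shown here alone, whether the step belongs to the chlorine, to the aromatic ring or simply to the drop from 7 heavy atoms to 3 stays open, and a plain phenyl in this place would begin to separate these. How a larger saturated ring such as cyclohexyl, or an amine on the same chain carbon, would read at this position also remains an open question.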